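The source may report more compounds than this note shows. Statements on the series, on what has been measured and on what is new or still open speak of the compounds shown alone.

Measured compounds in an assay on isolated protein for binding affinity to 5-hydroxytryptamine receptor 6 (Homo sapiens); a higher number here means a weaker inhibitor, a lower number a stronger inhibitor:
- compound 1, `COc1ccc(S(=O)(=O)Nc2cccc(I)c2)cc1N1CCNCC1`, gives 0.501 nM
- compound 2, `COc1ccc(Cl)cc1NS(=O)(=O)c1ccc(OC)c(N2CCNCC2)c1`, gives 1.26 nM
- compound 3, `COc1ccc(S(=O)(=O)Nc2cc(Cl)cc(Br)c2Cl)cc1N1CCNCC1`, gives 2 nM

Compound 3 carries the highest of the three numbers in this assay. Its nearest neighbour is compound 2, and the step of a 1.6-fold higher number from compound 2 to compound 3 (0.20 log units; within the scatter) lies within the scatter. Its furthest neighbour is compound 1, and the step of a 4.0-fold higher number from compound 1 to compound 3 (0.60 log units; beyond the scatter) lies beyond the scatter, as does a 2.5-fold higher number from compound 1 to compound 2 (0.40 log units; beyond the scatter).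

Compound 4, `COc1ccc(S(=O)(=O)Nc2cc(Br)cc(Cl)c2Br)cc1N1CCNCC1`, has not yet been measured. It differs from compound 3 in one place: 2,5-dibromo-3-chlorophenyl in place of 3-bromo-2,5-dichlorophenyl on a sulfonamide nitrogen. Going by the values given here, no measured step makes exactly this swap of halogens; the nearest comparison is compound 2 to compound 3, in which a different polyhalogenated ring replaced a chlorinated methoxyphenyl ring and the number moved within the scatter. Moving among such rings has so far given modest steps at most. For compound 4 in this assay the step of no change at the digits printed from compound 3 to compound 4 (within the scatter) is therefore expected to be small, with no direction beyond the scatter. Compound 4 is estimated to give 2 nM, within a range from 0.9 nM to 4.5 nM.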

Compound 4, inhibition constant: 3.98 nM
The estimate for compound 4 lay 2.0-fold (0.30 log units) below the measured number, and the stated range covers the measured number.
By their numbers in this assay, from the lowest: compound 1; then compounds 2, 3 and 4 (each within the scatter of the next, the first and the last beyond it).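

In this assay, putting 2,5-dibromo-3-chlorophenyl in place of 3-bromo-2,5-dichlorophenyl on a sulfonamide nitrogen gives a 2.0-fold higher number from compound 3 to compound 4 (0.30 log units; within the scatter) and so shows no readable shift between these two polyhalogenated rings. Even so, the ring in compound 4 stands clear of the other two rings, with a 3.2-fold higher number from compound 2 to compound 4 (0.50 log units; beyond the scatter) and a 7.9-fold higher number from compound 1 to compound 4 (0.90 log units; beyond the scatter) as the step to compound 3's ring partner compound 2 and the widest step seen at this position, whereas compound 3 stayed within the scatter of compound 2. No measurement shown here offers an explanation for these steps.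

The compounds shown leave open how an unsubstituted phenyl would fare at this position in this assay. They also leave open whether a phenyl carrying an amine or a carboxylic acid would be accepted on the sulfonamide nitrogen.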